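This account rests on a few compounds, and the source may have more. Where it says the series, first, only, none or still open, it means among the compounds named here.

Among the measured compounds shown here, compound 2 `Fc1ccccc1-c1ccc(Cn2nnc3ccccc32)cn1` sits at the top of the two numbers so far: in a functional assay on cells for positive allosteric modulation of metabotropic glutamate receptor 2 (Homo sapiens), read by fluorescence and calcium flux, with a stated time of 30 min (a lower number here means that less compound is needed, a higher number that more compound is needed for the effect), compound 2 gives 600 nM, while compound 1 `Fc1cc(Cl)ccc1-c1ccc(Cn2nnc3ccccc32)cn1` gives 50 nM. For the measured compounds named here, the only measured step, a 12-fold higher number from compound 1 to compound 2 (1.08 log units; beyond the scatter), removed a chloro group. Compound 3 `Clc1ccc(-c2ccc(Cn3nnc4ccccc43)cn2)cc1` reverses part of that loss: 4-chlorophenyl in place of 2-fluorophenyl on an aromatic carbon, so a chloro re-enters the ring while the fluorine leaves. Since the chloro-bearing compound 1 gave 50 nM, a substantial drop in the number is expected for compound 3 in this assay, estimated as a 4.0-fold lower number from compound 2 to compound 3 (0.60 log units; beyond the scatter). Compound 3 is therefore expected at 150 nM, within 40 nM to 600 nM.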

Compound 3, half-maximal effective concentration: 70 nM
Estimate against measurement, compound 3: 2.1-fold (0.33 log units) above; low and high end bracket the measured number.
By their numbers in this assay, from the lowest: compounds 1 and 3 (each within the scatter of the next); then compound 2.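

In this assay the exchange of 2-fluorophenyl for 4-chlorophenyl gives an 8.6-fold lower number from compound 2 to compound 3 (0.93 log units; beyond the scatter) and so shows that the chloro group brings the gain without the fluoro group on the ring. Taking the fluoro group away gives a 1.4-fold higher number from compound 1 to compound 3 (0.15 log units; within the scatter) and leaves it no readable part once chloro is present. On these data alone, whether a methoxy group or an amine in place of the chloro group would do as well stays open, as does the effect of chloro elsewhere on that ring. Nothing at hand explains the effect of the chloro group.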